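Fluoro Added to the Central Ring of Compound 1

The source may report more compounds than this note shows. Statements on the series, on what has been measured and on what is new or still open speak of the compounds shown alone.

Of the compounds shown here, three have been measured in a functional assay on MCF7 cells (Homo sapiens) for cytotoxicity, read by MTT assay, with a stated time of 72 h; on this read-out higher numbers stand for weaker inhibition and lower numbers for stronger inhibition. Compound 1 `O=C(Nc1ccc(Oc2ccnc3[nH]ccc23)cc1)c1cc(-c2ccc(Cl)cc2)ncn1` gives 7770 nM in this assay, the highest number of the three and therefore the weakest inhibition among them. Compound 2 `O=C(Nc1ccc(Oc2ccnc3[nH]ccc23)cc1)c1cc(-c2ccc(Br)cc2)ncn1` gives 3840 nM in this assay, and compound 3 `Cc1ccc(-c2cc(C(=O)Nc3ccc(Oc4ccnc5[nH]ccc45)cc3)ncn2)cc1` gives 1620 nM in this assay. For the measured compounds named here, the measured steps are a 2.0-fold lower number from compound 1 to compound 2 (0.31 log units; beyond the scatter), a 4.8-fold lower number from compound 1 to compound 3 (0.68 log units; beyond the scatter) and a 2.4-fold lower number from compound 2 to compound 3 (0.37 log units; beyond the scatter), and every one of them exchanges the single group at the outer end of the molecule while leaving the rest untouched.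

Compound 4 `O=C(Nc1ccc(Oc2ccnc3[nH]ccc23)c(F)c1)c1cc(-c2ccc(Cl)cc2)ncn1` is built from compound 1 by a change at a different place: fluoro in place of hydrogen on an aromatic carbon. The new fluorine sits on the central ring, ortho to a large group and meta to a large group. None of the three measured steps alters this part of the molecule, so they give no direct guide to the size or the direction of the effect. Going by the values given here, with no comparable step available, the expectation is a change that stays within the usual scatter, an estimated step of a 1.1-fold lower number from compound 1 to compound 4 (0.05 log units; within the scatter). Compound 4 is therefore expected to give about 7000 nM in this assay, with a range from 2500 nM to 20000 nM.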

Compound 4, half-maximal inhibitory concentration: 26900 nM
For compound 4 the middle estimate is 3.8-fold (0.58 log units) below the measured one; measured number outside the range, above it.
By their numbers in this assay, from the lowest: compound 3; then compound 2; then compound 1; then compound 4.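

In this assay the central ring turns out to be a part of the molecule that responds to even a small edit: one fluorine atom in place of hydrogen, ortho to a large group and meta to a large group, gives a 3.5-fold higher number from compound 1 to compound 4 (0.54 log units; beyond the scatter) and so weaker inhibition. For the compounds shown here, this is the only step from compound 1 that goes towards a higher number, while the two changes at the outer end, a 2.0-fold lower number from compound 1 to compound 2 (0.31 log units; beyond the scatter) and a 4.8-fold lower number from compound 1 to compound 3 (0.68 log units; beyond the scatter), both go the other way, so the direction of a change cannot be carried over from one part of the molecule to another. Nothing available on these compounds explains how so small an addition shifts the cytotoxicity read-out.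

As far as these compounds go, it remains open whether this loss belongs to fluoro in particular or would appear with any group on this carbon, a question that a methoxy group or an amine at the same place could help to settle. Also open, from the compounds shown here alone, is whether fluoro on the central ring would shift the number by a similar amount when the outer group is bromo or methyl instead of chloro.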